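Taking the hydroxy group away from compound 2

The source may report more compounds than this note shows. Statements on the series, on what has been measured and on what is new or still open speak of the compounds shown alone.

In a functional assay on MGC-803 cells (Homo sapiens) for cytotoxicity, read by MTT assay, with a stated time of 72 h (on this read-out higher numbers stand for weaker inhibition and lower numbers for stronger inhibition), compound 1 `O=C1C(=Cc2ccc(O)cc2)C(=O)N(c2ccc(Cl)cc2)N1c1ccc(Cl)cc1` gives 19500 nM. Compound 2 `COc1cc(C=C2C(=O)N(c3ccc(Cl)cc3)N(c3ccc(Cl)cc3)C2=O)ccc1O` gives 21800 nM, so the two stand level within the scatter. Compound 3 `COc1cccc(C=C2C(=O)N(c3ccc(Cl)cc3)N(c3ccc(Cl)cc3)C2=O)c1` differs from compound 2 as follows: hydrogen in place of hydroxy on an aromatic carbon. This is hydrogen in place of hydroxy on an aromatic carbon, turning 4-hydroxy-3-methoxyphenyl into 3-methoxyphenyl. Within the data shown here, only one measured step bears on this, and only indirectly: a 1.1-fold higher number from compound 1 to compound 2 (0.05 log units; within the scatter), which is methoxy in place of hydrogen on an aromatic carbon, with the hydroxy kept. Among the measured compounds shown here, no measured compound lacks the hydroxy, so its removal remains untested. For the measured compounds named here, with that single small step as the only guide, no change beyond the scatter is expected in this assay, though the uncertainty is wide. The expected step is a 1.1-fold higher number from compound 2 to compound 3 (0.06 log units; within the scatter). Compound 3 is estimated at 25000 nM, with a range from 9000 nM to 60000 nM.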

Compound 3, half-maximal inhibitory concentration: 26600 nM
Compound 3: middle estimate off by 1.1-fold (0.03 log units), on the low side; the range from low to high includes it.
By their numbers in this assay, from the lowest: compounds 1, 2 and 3 (each within the scatter of the next).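

In this assay, the hydroxy group is now tested directly, and its removal gives a 1.2-fold higher number from compound 2 to compound 3 (0.09 log units; within the scatter), so hydrogen and hydroxy on this aromatic carbon cannot be told apart in this assay. Replacing 4-hydroxyphenyl with 3-methoxyphenyl gives a 1.4-fold higher number from compound 1 to compound 3 (0.13 log units; within the scatter), so even this combined change of the ring substituents leaves compound 3 level with compound 1 within the scatter. No available evidence accounts for this flat result.

Hydrogen, hydroxy and methoxy are the only substituents shown on this ring, so it remains open whether an amine, a carboxylic acid or a longer alkoxy chain would move the number beyond the scatter. The compounds also leave open how far the rest of the core of compound 1 governs the read-out, since it stays the same throughout.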